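Bromo in Place of Fluoro on Compound 2

A few compounds are considered here, and "the series" means these few. Any claim that something is new, unique, unknown or untested is made for them only; others in the source may bear on it.

Compound 2 `O=C1N(Cc2ccc(Cl)cc2Cl)c2cccn2S(=O)(=O)N1Cc1cccc(F)c1` was tested in an ADME assay on MT4 cells (Homo sapiens) for cytotoxicity, read by MTT assay, with a stated time of 5 days (on this read-out lower numbers stand for higher toxicity in this test and higher numbers for lower toxicity in this test), and its result of > 249000 nM is a limit of the assay rather than a number. Compound 1 `O=C1N(Cc2cccc(Cl)c2)c2cccn2S(=O)(=O)N1Cc1cccc(F)c1` gives 208000 nM in this assay. For compound 3 `N#Cc1ccccc1CN1C(=O)N(Cc2cccc(F)c2)S(=O)(=O)n2cccc21` the result of > 305000 nM is likewise only a limit. The two measured steps that touch compound 2 are an at least 1.1-fold higher number from compound 1 to compound 2 (0.07 log units; that floor lies within the scatter) and a step that the two limits leave unreadable from compound 2 to compound 3; both alter the other benzyl group, not the one changed here. Compound 4 `O=C1N(Cc2ccc(Cl)cc2Cl)c2cccn2S(=O)(=O)N1Cc1cccc(Br)c1` differs from compound 2 by bromo in place of fluoro on an aromatic carbon. Within the data shown here, with no measured step at this position, no change beyond the scatter is expected, so the step that the limit leaves unreadable from compound 2 to compound 4 is expected to stay near the limit. Compound 4 is therefore estimated at 250000 nM, in a range from 120000 nM to 450000 nM.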

Compound 4, half-maximal cytotoxic concentration: > 243000 nM
Compound 4: no number, only a limit; the forecaster's own chance of this, stated with the estimate: 60%; the middle value lies beyond the limit too.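

Among these compounds, compound 2 and compound 4 each end in a limit of the assay rather than a number, so no step between them can be read. Going by these compounds, whether bromo in place of fluoro changes the cytotoxicity read-out at all stays open.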